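The source may hold more compounds than are shown below. What is called first, only, known or untested is meant among the compounds shown, and "the series" means these compounds.

Measured compounds:
Compound 1, `COc1ccc(CN(c2cc(OC)c(OC)c(OC)c2)S(=O)(=O)c2ccc(C(C)(C)C)cc2)cc1`: 32700 nM
Compound 2, `COc1ccc(CN(c2cc(OC)c(OC)c(OC)c2)S(=O)(=O)c2ccc(OC)c(OC)c2)cc1`: 22700 nM
Compound 3, `COc1cc(N(Cc2nc3ccccc3[nH]2)S(=O)(=O)c2ccc(C(C)(C)C)cc2)cc(OC)c1OC`: 33600 nM

All three compounds were tested in a functional assay on MCF7 cells (Homo sapiens) for inhibition, read by MTT assay, with a stated time of 48 h; a lower number here means a stronger inhibitor, a higher number a weaker inhibitor. Compound 1 gives 32700 nM, compound 2 gives 22700 nM and compound 3 gives 33600 nM. The step of a 1.4-fold lower number from compound 1 to compound 2 (0.16 log units; within the scatter) comes from one change, (3,4-dimethoxyphenyl in place of 4-(tert-butyl)phenyl on a sulfonyl sulfur). The step of a 1.0-fold higher number from compound 1 to compound 3 (0.01 log units; within the scatter) comes from a different change, (1H-benzimidazol-2-yl in place of 4-methoxyphenyl on a saturated chain carbon bound to a sulfonamide nitrogen), which is also how the core of compound 3 differs from the core of compound 1. Among the three, none is set apart: every step between them is within the scatter, so no order can be read from these numbers.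

The unmeasured compound 4, `COc1ccc(S(=O)(=O)N(Cc2nc3ccccc3[nH]2)c2cc(OC)c(OC)c(OC)c2)cc1OC`, is to be tested in this assay. It stands to compound 3 as compound 2 stands to compound 1: the change is 3,4-dimethoxyphenyl in place of 4-(tert-butyl)phenyl on a sulfonyl sulfur, at the same place on the sulfonyl sulfur with the same neighbour, so it is the same change made on the other core. Among the measured compounds shown here, the only guide for what it might do is compound 1 to compound 2, which gave a 1.4-fold lower number from compound 1 to compound 2 (0.16 log units; within the scatter), a step within the scatter. Since that single example is all that is known, and the two cores gave near-identical numbers for compound 1 and compound 3, the step from compound 3 to compound 4 is expected to be of the same modest size, a 1.3-fold lower number from compound 3 to compound 4 (0.13 log units; within the scatter), resting on the step of a 1.4-fold lower number from compound 1 to compound 2 (0.16 log units; within the scatter). Compound 4 is therefore estimated at 25000 nM, with the expected range running from 12000 nM to 50000 nM.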

Compound 4, half-maximal inhibitory concentration: 47700 nM
For compound 4 the middle estimate is 1.9-fold (0.28 log units) below the measured one, within the range that was stated.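

Placing 3,4-dimethoxyphenyl in place of 4-(tert-butyl)phenyl on a sulfonyl sulfur gives, on the core of compound 3 in this assay, a 1.4-fold higher number from compound 3 to compound 4 (0.15 log units; within the scatter), and this step cannot be told apart from the one seen on the core of compound 1: the same change on two cores in this assay, a 1.4-fold lower number (0.16 log units; within the scatter) from compound 1 to compound 2 and a 1.4-fold higher number (0.15 log units; within the scatter) from compound 3 to compound 4, 2.0-fold (0.31 log units) apart, within the scatter of two such steps The other change, 1H-benzimidazol-2-yl in place of 4-methoxyphenyl on a saturated chain carbon bound to a sulfonamide nitrogen, gives a 2.1-fold higher number from compound 2 to compound 4 (0.32 log units; beyond the scatter), a modest step beyond the scatter, but it too cannot be told apart from its earlier counterpart: the same change on two cores in this assay, a 1.0-fold higher number (0.01 log units; within the scatter) from compound 1 to compound 3 and a 2.1-fold higher number (0.32 log units; beyond the scatter) from compound 2 to compound 4, 2.0-fold (0.31 log units) apart, within the scatter of two such steps The four compounds therefore give no evidence that either change depends on the core, yet they do not prove that either carries over unchanged, since each comparison rests on a single pair of steps and neither sulfonyl step can be given a direction.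

On these data alone, it remains open whether an amine or a carboxylic acid on the ring attached to the sulfonyl sulfur would produce a step clearly beyond the scatter on both cores. Also open, as far as these compounds go, is whether a longer chain between the sulfonamide nitrogen and the 1H-benzimidazol-2-yl group would behave in the same way on these cores.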